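This account rests on a few compounds, and the source may have more. Where it says the series, first, only, none or still open, it means among the compounds named here.

Working notes on the series. Of the compounds shown here, two have numbers so far in an assay on isolated protein for inhibition of Leucine-rich repeat serine/threonine-protein kinase 2 (Homo sapiens), read by TR-FRET and LanthaScreen, with stated times of 50 min and 30 min, in the presence of a further agent that is not named here; on this read-out lower numbers stand for stronger inhibition and higher numbers for weaker inhibition. Compound 1, `C[C@@H]1CCCN1c1c(C#N)c2c(N)nc(Nc3ccn(C)n3)cc2n1C`, gives 234 nM in this assay. Compound 2, `Cc1c(Nc2nc(N)c3c(C#N)c(N4CCC[C@H]4C)n(C)c3n2)cnn1[C@@H]1CCOC1`, gives 20 nM in this assay, which is the lowest of the two numbers shown; the nearest is compound 1, a gap beyond the scatter. No step between measured compounds that differ in a single place is available, so nothing shown tells how a change of configuration alone moves the read-out.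

The next compound, compound 3, `Cc1c(Nc2nc(N)c3c(C#N)c(N4CCC[C@H]4C)n(C)c3n2)cnn1[C@H]1CCOC1`, is not yet measured in this assay. It differs from compound 2 as follows: the two compounds have the same atoms and bonds and differ only in configuration as drawn: 1 of 2 stereo elements differ; a stereocentre at a saturated ring carbon is drawn R in compound 2 and S in compound 3. For the measured compounds named here, with no measured pair of this kind to lean on, the expectation is that the step from compound 2 to compound 3 in this assay is small to moderate, most likely toward a higher number, and may well fall within the scatter. Compound 3 is thus expected to give around 50 nM in this assay, within a range of 15 nM to 250 nM, the expected step being a 2.5-fold higher number from compound 2 to compound 3 (0.40 log units; beyond the scatter).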

Compound 3, half-maximal inhibitory concentration: 23 nM
For compound 3 the middle estimate is 2.2-fold (0.34 log units) above the measured one; the range from low to high includes it.
By their numbers in this assay, from the lowest: compounds 2 and 3 (each within the scatter of the next); then compound 1.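

In this assay, for the compounds shown here, inverting the stereocentre at the saturated ring carbon from R to S gives the first single-place step: a 1.2-fold higher number from compound 2 to compound 3 (0.06 log units; within the scatter). On this read-out, the configuration drawn at this carbon therefore does not separate the two compounds, and neither drawing can be preferred on the strength of these numbers. The step can be read as the effect of this single stereocentre, with no other change mixed in, because of one fact: the fact that compounds 2 and 3 differ only in the configuration as drawn.

Still open, going by these compounds, is whether the same indifference holds when the ring carrying this carbon gives way to another group, such as an isopropyl group or a ring bearing a basic amine, since one pair at one position says nothing about how the read-out responds to a change of group there. Also open, on these data alone, is how the read-out responds to inversion of the second stereocentre, which is drawn the same in compound 2 and compound 3, and whether the two configurations at the saturated ring carbon stay level on any read-out other than this binding measurement.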